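Pyridine nitrogen moved on the hydrazone carbon

This account rests on a few compounds, and the source may have more. Where it says the series, first, only, none or still open, it means among the compounds named here.

Compound 3 `O=C(N/N=C/c1cccnc1)c1cccnc1Nc1cccc(C(F)(F)F)c1` gives 52.4% in a functional assay on the whole organism (strain Wistar) for inhibition, with Rattus norvegicus as the target, read by paw edema, with a stated time of 3 h, at a dose of 10 mg/kg by the intraperitoneal route; a lower number here means less inhibition, a higher number more inhibition at the dose given (going by the name of the read-out). It sits between the other two compounds, though its gap to compound 1 `O=C(N/N=C/c1cccc(Cl)c1)c1cccnc1Nc1cccc(C(F)(F)F)c1`, which gives 55.2%, is within the scatter; compound 2 `O=C(N/N=C/c1ccc(O)c(O)c1)c1cccnc1Nc1cccc(C(F)(F)F)c1` gives 38.2%, and the step of a number 14.2 percentage points higher from compound 2 to compound 3 (beyond the scatter) is modest.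

Compound 4 `O=C(N/N=C/c1ccncc1)c1cccnc1Nc1cccc(C(F)(F)F)c1` keeps every atom of compound 3 and rearranges one ring: pyridin-4-yl in place of pyridin-3-yl on a carbon with a double bond to nitrogen. For the measured compounds named here, the only step at this position that bears on it is a number 2.8 percentage points lower from compound 1 to compound 3 (within the scatter), which stayed within the scatter, and no measured pair moves a ring nitrogen within the same ring. A step of no more than the scatter is therefore expected, a number 2.4 percentage points lower from compound 3 to compound 4 (within the scatter). Compound 4 is estimated at 50%, expected between 38% and 62%.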

Compound 4, a percentage reported as inhibition, in the whole organism at one dose (the size of the read-out at that dose, not a potency): 54.9%
Estimate against measurement, compound 4: 4.9 percentage points below, within the range that was stated.
By their numbers in this assay, from the lowest: compound 2; then compounds 3, 4 and 1 (each within the scatter of the next).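

In this assay, for the compounds shown here, pyridin-4-yl in place of pyridin-3-yl, the one pair here that moves a ring nitrogen within the same ring, gives a number 2.5 percentage points higher from compound 3 to compound 4 (within the scatter) and so shows no readable effect of that move. Pyridin-4-yl likewise shows a number 0.3 percentage points lower from compound 1 to compound 4 (within the scatter) but stands apart from 3,4-dihydroxyphenyl with a number 16.7 percentage points higher from compound 2 to compound 4 (beyond the scatter), leaving compound 2 alone among the four at this position. No supporting data bear on the reason for these steps.

Still open, from the compounds shown here alone, is whether pyridin-2-yl, a single hydroxyl, or a phenyl ring carrying an amine or a carboxylic acid would stay level with compound 4 or fall towards compound 2.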